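Trading an Acetylsulfanyl Side Chain for a Methylsulfanyl Chain

The compounds below may be only part of what the source reports. "The series", "measured", "known", "first", "only" and "open" are said of these compounds alone.

Three cyclic peptides of one shared core have been tested in a functional assay on P388 cells (Mus musculus) for cytotoxicity; on this read-out lower numbers stand for stronger inhibition and higher numbers for weaker inhibition. Compound 1, `COc1ccc(C[C@H]2C(=O)N[C@@H](C)C(=O)N(C)[C@H]3Cc4ccc(cc4)Oc4cc(ccc4OC)C[C@@H](C(=O)N[C@H](C)C(=O)N[C@@H](CSC(C)=O)C(=O)N2C)N(C)C3=O)cc1`, gives 9.77 nM, the lowest of the three numbers. Compound 2, `CCC[C@@H]1NC(=O)[C@@H](C)NC(=O)[C@@H]2Cc3ccc(OC)c(c3)Oc3ccc(cc3)C[C@@H](C(=O)N2C)N(C)C(=O)[C@H](C)NC(=O)[C@H](Cc2ccc(OC)cc2)N(C)C1=O`, gives 13.8 nM, and compound 3, `C=C[C@@H]1NC(=O)[C@@H](C)NC(=O)[C@@H]2Cc3ccc(OC)c(c3)Oc3ccc(cc3)C[C@@H](C(=O)N2C)N(C)C(=O)[C@H](C)NC(=O)[C@H](Cc2ccc(OC)cc2)N(C)C1=O`, gives 25.7 nM. The steps are a 1.4-fold higher number from compound 1 to compound 2 (0.15 log units; within the scatter) and a 2.6-fold higher number from compound 1 to compound 3 (0.42 log units; beyond the scatter), and also a 1.9-fold higher number from compound 2 to compound 3 (0.27 log units; within the scatter). Compound 4, `COc1ccc(C[C@H]2C(=O)N[C@@H](C)C(=O)N(C)[C@H]3Cc4ccc(cc4)Oc4cc(ccc4OC)C[C@@H](C(=O)N[C@H](C)C(=O)N[C@@H](CCSC)C(=O)N2C)N(C)C3=O)cc1`, differs from compound 1 by (methylsulfanyl)methyl in place of acetylsulfanyl on a saturated chain carbon bound to a saturated ring carbon. Replacing the acetylsulfanyl side chain of compound 1 with a plain hydrocarbon chain in compound 2 cost little, so a chain of similar length carrying a sulfur atom is expected to behave alike. The expected step is a 1.3-fold higher number from compound 1 to compound 4 (0.12 log units; within the scatter), and compound 4 is estimated at 13 nM, with a range from 6 nM to 30 nM.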

Compound 4, half-maximal inhibitory concentration: 20.4 nM
The estimate for compound 4 lay 1.6-fold (0.20 log units) below the measured number, within the range that was stated.
By their numbers in this assay, from the lowest: compounds 1, 2, 4 and 3 (each within the scatter of the next, the first and the last beyond it).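

Keeping a sulfur atom in the chain does not hold the number of compound 1 (a 2.1-fold higher number from compound 1 to compound 4 (0.32 log units; beyond the scatter)). Against the plain hydrocarbon chain, the methylsulfanyl group makes no clear difference (a 1.5-fold higher number from compound 2 to compound 4 (0.17 log units; within the scatter)), and the same holds against vinyl (a 1.3-fold lower number from compound 3 to compound 4 (0.10 log units; within the scatter)), so compounds 2, 3 and 4 all sit within the scatter of one another. No measurement at hand explains these numbers. From the compounds shown here alone, whether an amine, a carboxylic acid or a longer chain at this place would move the number beyond that scatter remains open.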